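This account rests on a few compounds, and the source may have more. Where it says the series, first, only, none or still open, it means among the compounds named here.

Compound 1, `CN(Cc1cccc(F)c1)C(=O)CCCNC(=O)c1ccc(S(C)(=O)=O)c([N+](=O)[O-])c1`, in an assay on isolated protein for inhibition of thyroid hormone receptor beta (Homo sapiens), read by fluorescence polarization (a lower number here means a stronger inhibitor, a higher number a weaker inhibitor), gives > 60000 nM, which is a limit of the assay rather than a number.
Compound 2, `CC(C)N(C(=O)CCNC(=O)c1ccc(S(C)(=O)=O)c([N+](=O)[O-])c1)C(C)C`, in this assay gives > 60000 nM, again only a limit.

Compound 2 therefore stands where the assay stops reporting a number. Going by the values given here, compound 1 and compound 2 differ in more than one place, so no single step joins them; their two values show only that neither reaches a measurable concentration, and the limit of > 60000 nM in this assay, at which 2 of the 2 values shown sit, describes where both sit.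

Compound 3, `CS(=O)(=O)c1ccc(C(=O)NCCCC(=O)N2CCCCC2)cc1[N+](=O)[O-]`, is not yet measured. It keeps the core of compound 2 and carries ((piperidin-1-yl)carbonyl)methyl in place of diisopropylcarbamoyl on a saturated chain carbon, two bonds along the chain from an amide-type nitrogen. Among the compounds with values here, no measured step between compounds is available to guide this change. Because both measured values sit at the limit of > 60000 nM in this assay, at which 2 of the 2 values shown sit, the step that the limit leaves unreadable from compound 2 to compound 3 is expected to be none beyond the usual scatter, with the readout most likely once more a limit. Compound 3 is thus estimated at about 80000 nM, within 30000 nM to 250000 nM.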

Compound 3, half-maximal inhibitory concentration: > 60000 nM
Compound 3 was reported as a limit; the forecaster's own chance of this, stated with the estimate: 85%; the middle value lies beyond the limit too.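

No size can be read for the steps from compound 1 or compound 2 to compound 3, since all three values are limits rather than numbers: the limit of > 60000 nM in this assay, at which 3 of the 3 values shown sit.

The compounds shown leave open how far each lies beyond that limit, and whether any change to these groups gives a measurable inhibitor.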